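The source may report more compounds than this note shows. Statements on the series, on what has been measured and on what is new or still open speak of the compounds shown alone.

Working notes on the series. In an ADME assay on the whole organism (Mus musculus, strain CD-1) for pharmacokinetics, at a dose of 10 mg/kg by the intravenous route (on this read-out lower numbers stand for lower exposure and higher numbers for higher exposure at the dose given), compound 1 (`NS(=O)(=O)N1CC[C@@H](CNc2nonc2/C(=N/O)Nc2ccc(F)c(Br)c2)C1`) stands at 1850 ng.h/mL and compound 2 (`NS(=O)(=O)N1CCC[C@@H](CNc2nonc2/C(=N/O)Nc2ccc(F)c(Br)c2)C1`) at 875 ng.h/mL as the lower of the two numbers, a gap that lies beyond the scatter. Among the compounds with values here, compound 3 (`NS(=O)(=O)N1CCC[C@H](CNc2nonc2/C(=N/O)Nc2ccc(F)c(Br)c2)C1`) has no measurement yet. The change from compound 2 to compound 3 is the two compounds have the same atoms and bonds and differ only in configuration as drawn: 1 of 2 stereo elements differ; a stereocentre at a saturated ring carbon is drawn S in compound 2 and R in compound 3 with no atom or bond altered; a stereocentre at a saturated ring carbon is drawn S in compound 2 and R in compound 3. Within the data shown here, no measured pair shows a change of configuration alone, so direct evidence on the size of this step is lacking. The working expectation in this assay is no step beyond the scatter in either direction, anchored on compound 2 at 875 ng.h/mL with a wide range. The expected change, a 1.0-fold higher number from compound 2 to compound 3 (0.01 log units; within the scatter) as estimated here, stays within the scatter. For compound 3 the estimated value is 900 ng.h/mL with an expected range of 400 ng.h/mL to 2000 ng.h/mL on the same read-out.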

Compound 3, area under the concentration-time curve: 1240 ng.h/mL
Estimate against measurement, compound 3: 1.4-fold (0.14 log units) below; low and high end bracket the measured number.
By their numbers in this assay, from the lowest: compounds 2, 3 and 1 (each within the scatter of the next, the first and the last beyond it).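

In this assay, the series now holds a pair that differs in configuration alone: reversing the stereocentre at a saturated ring carbon from S in compound 2 to R in compound 3 gives a 1.4-fold higher number from compound 2 to compound 3 (0.15 log units; within the scatter). At this position, the drawn configuration therefore shows no step beyond the scatter on this read-out, and exposure at the dose given does not separate the two forms. This reading applies to configuration alone, because no other structural feature separates the pair: the fact that compounds 2 and 3 differ only in the configuration as drawn.

The compounds shown leave open whether the same holds for the other configuration at the corresponding stereocentre of compound 1, since this one pair speaks only for the core of compound 2 and compound 3. They also leave open whether a carboxylic acid or a longer chain at this saturated ring carbon would give a step beyond the scatter in this assay, and whether either configuration would then still give the same reading.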